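Fluoro removal on two hydrazone cores

This account rests on a few compounds, and the source may have more. Where it says the series, first, only, none or still open, it means among the compounds named here.

Compound 3 `O=C(N/N=C/c1ccccc1O)c1ccc(-c2ccc(F)cc2F)o1` gives 43.1% in a functional assay on HL-60 cells (Homo sapiens) for inhibition, read by MTT assay, with a stated time of 48 h, tested at 10 uM; a higher number here means more inhibition of growth at the concentration tested, a lower number less inhibition of growth. Compound 1 `O=C(N/N=C/c1ccccc1O)c1ccc(-c2ccc(F)cc2)o1` gives 13.1% in this assay; the step of a number 30 percentage points lower from compound 3 to compound 1 (beyond the scatter) goes with the change (hydrogen in place of fluoro on an aromatic carbon). Compound 2 `O=C(N/N=C/c1ccc(-c2ccc(F)cc2F)o1)c1ccccc1O` has the same atoms as compound 3 joined differently; the difference between the two cores is not broken down here. In this assay compound 2 gives -9.5%, the lowest of the three numbers. Compound 4 `O=C(N/N=C/c1ccc(-c2ccc(F)cc2)o1)c1ccccc1O` is not yet measured. From compound 2 to compound 4 the change is hydrogen in place of fluoro on an aromatic carbon, the same change as from compound 3 to compound 1. That earlier step was a modest drop, but the expected step here is only a number 2.5 percentage points lower from compound 2 to compound 4 (within the scatter), because compound 2 already stands at -9.5% and leaves little room for a further fall. Compound 4 is estimated at -12% in this assay, expected between -35% and 12%.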

Compound 4, percent growth inhibition at one concentration: -2.08%
Estimate against measurement, compound 4: 9.9 percentage points below, within the range that was stated.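

In this assay, the change from 2,4-difluorophenyl to 4-fluorophenyl does not carry over from one core to the other: the same change on two cores in this assay, a number 30 percentage points lower (beyond the scatter) from compound 3 to compound 1 and a number 7.4 percentage points higher (within the scatter) from compound 2 to compound 4, 37.4 percentage points apart, beyond the scatter of two such steps. Read alone, the new step is a number 7.4 percentage points higher from compound 2 to compound 4 (within the scatter), so no effect of removing this fluoro can be read on that core. For the compounds shown here, the two pairs show only that the step is not the same on these two cores; they do not show what in the cores sets the difference, or how the change would behave on any further core.

Open, on these data alone, is whether another group on that aromatic carbon, such as chloro, methoxy or an amine, would separate the two cores in the same way. Also open, as far as these compounds go, is how either core responds when the remaining fluoro is replaced by hydrogen.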